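Removing a methyl from a weak inhibitor of ECa-109 cell growth

The source may hold more compounds than are shown below. What is called first, only, known or untested is meant among the compounds shown, and "the series" means these compounds.

Of the compounds shown here, two have been tested in a functional assay on ECa-109 cells (Homo sapiens) for inhibition, read by MTT assay, with a stated time of 72 h; on this read-out lower numbers stand for stronger inhibition and higher numbers for weaker inhibition. Compound 1, `O=C(OCc1ccccc1)N1CCN(C(=S)SCc2cn(Cc3ccc(Cl)c(Cl)c3)nn2)CC1`, gives 29400 nM in this assay. Compound 2, `Cc1cc(=O)oc2cc(OCCn3cc(CSC(=S)N4CCN(C(=O)OC(C)(C)C)CC4)nn3)ccc12`, reaches only the limit of the assay, > 128000 nM, so no number is known for it. Within the two values shown, compound 2 therefore stands at the weak end, a point captured by the evidence that (the limit of > 128000 nM in this assay, at which 1 of the 2 values shown sits).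

Compound 3, `CC(C)(C)OC(=O)N1CCN(C(=S)SCc2cn(CCOc3ccc4ccc(=O)oc4c3)nn2)CC1`, has not been measured yet. It differs from compound 2 in one place: hydrogen in place of methyl on an aromatic carbon of the six-membered aromatic ring with one oxygen in the fused two-ring system. For the measured compounds named here, no measured pair shows what such a change does here. Because compound 2 sits at > 128000 nM, the expectation is that compound 3 stays similarly weak, with the step from compound 2 to compound 3 expected to be a step that the limit leaves unreadable from compound 2 to compound 3, within the usual scatter. Compound 3 is therefore estimated at 150000 nM, with a range from 50000 nM to 450000 nM.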

Compound 3, half-maximal inhibitory concentration: > 128000 nM
Compound 3 ended at the assay's limit; the forecaster's own chance of this, stated with the estimate: 70%; the middle value does not contradict the limit.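

Compound 2 and compound 3 both end at a limit of this assay rather than at a number, so the step between them cannot be read: the limit of > 128000 nM in this assay, at which 2 of the 3 values shown sit. The compounds shown leave open whether hydrogen in place of methyl on an aromatic carbon changes the inhibition of these cells at all.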